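Glycine cap on the benzylic amine of compound 1

The source may hold more compounds than are shown below. What is called first, only, known or untested is meant among the compounds shown, and "the series" means these compounds.

Measured so far:
compound 1 `CC[C@H](C)C(N)c1cc(C(F)(F)F)ccc1N1CCN(C(=O)CCc2ccc(Cl)cc2Cl)CC1`: 75 nM
compound 2 `COc1ccc(OC)c(CCC(=O)N2CCN(c3ccc(C(F)(F)F)cc3[C@@H](N)CC(C)C)CC2)c1`: 2500 nM

Among the measured compounds shown here, in an assay on HEK293 cells for displacement of a labelled ligand from Melanocortin receptor 4 (Homo sapiens) (on this read-out lower numbers stand for stronger inhibition and higher numbers for weaker inhibition), compound 1 gives 75 nM, the lower of the two numbers known. For the measured compounds named here, compound 2 gives 2500 nM in this assay, a gap to compound 1 that lies beyond the scatter; the two structures differ in more than one place, so no single step is drawn between them.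

Compound 3 `CCC(C)[C@H](NC(=O)CN)c1cc(C(F)(F)F)ccc1N1CCN(C(=O)CCc2ccc(Cl)cc2Cl)CC1` is not yet measured. It keeps the core of compound 1 with the 2,4-dichlorophenyl amide and changes only the side chain on the aromatic carbon: 1-(((aminomethyl)carbonyl)amino)-2-methylbutyl in place of 1-amino-2-methylbutyl on an aromatic carbon. The free amine that compound 1 carries is thus acylated, while a new aminomethyl group enters at the end of the chain.

Going by the values given here, no measured pair shows an acylation of this kind, so the direction rests on compound 1 alone. A modest weakening is expected, in the range of a small step in this assay, as the added carbonyl and second nitrogen change the group that sits ortho to the large piperazine substituent. The step from compound 1 to compound 3 is expected as a 2.7-fold higher number from compound 1 to compound 3 (0.43 log units; beyond the scatter). For compound 3 the estimate in this assay is 200 nM, with a range from 60 nM to 700 nM.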

Compound 3, inhibition constant: 18 nM
Compound 3: middle estimate off by 11-fold (1.05 log units), on the high side; measured number outside the range, below it.
By their numbers in this assay, from the lowest: compound 3; then compound 1; then compound 2.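

The side chain on the aromatic carbon, ortho to a large group, accepts acylation of its amine: in this assay, 1-(((aminomethyl)carbonyl)amino)-2-methylbutyl in place of 1-amino-2-methylbutyl gives a 4.2-fold lower number from compound 1 to compound 3 (0.62 log units; beyond the scatter). Among the compounds shown here, until now the series held only side chains with an unacylated amine at this carbon, so this is the first sign that the position can take a larger group, here 10 heavy atoms against 6, with no loss in this read-out and a gain beyond the scatter. No data on hand bear on what lies behind this step.

The single change adds both a carbonyl and a terminal aminomethyl group, so the compounds shown do not separate the contribution of the amide from that of the terminal amine; a plain acetyl cap, which has no terminal amine, or a longer amino-acid chain such as a 3-aminopropanoyl cap would address this. From the compounds shown here alone, it also remains open whether the same cap carries over to the 2,5-dimethoxyphenyl amide of compound 2, which differs from compound 1 in more than one place.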